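Amide substituent swap on the shared core, compound 4

The source may report more compounds than this note shows. Statements on the series, on what has been measured and on what is new or still open speak of the compounds shown alone.

Compound 1 `CCn1c(C(=O)N[C@@H](C)C(=O)OC)ccc1C(CC)(CC)c1ccc(OCS(=O)(=O)c2ccccc2)c(C)c1` carries a 1-(methoxycarbonyl)ethyl group on the amide-type nitrogen. In a functional assay on PC-3 cells (Homo sapiens) for antiproliferative activity, read by MTT assay, with a stated time of 24 h (on this read-out higher numbers stand for weaker inhibition and lower numbers for stronger inhibition), compound 1 gives > 50000 nM, which is a limit of the assay and not a number. Compound 1 therefore stands at the limit of > 50000 nM in this assay, at which 1 of the 3 values shown sits.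

Two measured neighbours replace that group. Compound 2 `CCN(CC)CCNC(=O)c1ccc(C(CC)(CC)c2ccc(OCS(=O)(=O)c3ccccc3)c(C)c2)n1CC` gives 7130 nM in this assay, and compound 3 `CCn1c(C(=O)N[C@@H](CO)C(C)C)ccc1C(CC)(CC)c1ccc(OCS(=O)(=O)c2ccccc2)c(C)c1` gives 10600 nM. The step of an at least 7.0-fold lower number from compound 1 to compound 2 (0.84 log units; beyond the scatter) and the step of an at least 4.7-fold lower number from compound 1 to compound 3 (0.67 log units; beyond the scatter) both move off the limit to a measurable number, while the step of a 1.5-fold higher number from compound 2 to compound 3 (0.17 log units; within the scatter) shows the two replacement groups give similar results.

Compound 4 `CCn1c(C(=O)N[C@H](CO)CCCO)ccc1C(CC)(CC)c1ccc(OCS(=O)(=O)c2ccccc2)c(C)c1` is not yet measured. The change is a group of 7 heavy atoms (5 carbon, 2 oxygen; no ring) in place of a group of 6 heavy atoms (4 carbon, 2 oxygen; no ring), on an amide-type nitrogen. Like compound 3, the entering group carries hydroxyl groups rather than the methoxycarbonyl of compound 1, so the steps from compound 1 to compound 2 and from compound 1 to compound 3 are the ones that bear on it. Both were at least modest and in the same direction, so a similar step downward is expected for compound 4, namely an at least 4.1-fold lower number from compound 1 to compound 4 (0.61 log units; beyond the scatter). Compound 4 is thus estimated at 12000 nM in this assay, with a plausible range from 4000 nM to 40000 nM, a modest chance remaining that only a limit is returned.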

Compound 4, half-maximal inhibitory concentration: 6810 nM
Estimate against measurement, compound 4: 1.8-fold (0.25 log units) above, and the stated range covers the measured number.
By their numbers in this assay, from the lowest: compounds 4, 2 and 3 (each within the scatter of the next). At a limit, above all of these: compound 1.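

In this assay, a third replacement for 1-(methoxycarbonyl)ethyl on the amide-type nitrogen also gives a measurable number, with the step of an at least 7.3-fold lower number from compound 1 to compound 4 (0.86 log units; beyond the scatter), so leaving the limit does not depend on one particular entering group among the three shown. The steps of a 1.6-fold lower number from compound 3 to compound 4 (0.19 log units; within the scatter) and a 1.0-fold lower number from compound 2 to compound 4 (0.02 log units; within the scatter) show that the entering group of compound 4, with its 2 hydrogen-bond donors, cannot be told apart in this read-out from either 1-(hydroxymethyl)-2-methylpropyl or 2-(diethylamino)ethyl, even though the last of these carries an amine. Compound 1 remains the only compound at a limit, which is not a number: the limit of > 50000 nM in this assay, at which 1 of the 4 values shown sits.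

The shown compounds do not separate the loss of the methoxycarbonyl from the entry of any particular replacement group, since a carboxylic acid in its place and a plain butyl chain on the same nitrogen are absent from this set. Going by these compounds, how far the number can fall at this position also stays open, as all three replacements sit within the scatter of one another.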